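A Change of Configuration Alone: Compound 2 to Compound 3

A few compounds are considered here, and "the series" means these few. Any claim that something is new, unique, unknown or untested is made for them only; others in the source may bear on it.

In an ADME assay on a cell-free system (plasma, Homo sapiens) for metabolic stability, read by LC-MS (on this read-out higher numbers stand for a longer-lived compound and lower numbers for a shorter-lived compound), compound 1 (`COc1cc(/C=C/C(=O)O[C@H]2CC[C@H](N(C)CCCOC(=O)c3cc(OC)c(OC)c(OC)c3)CC2)cc(OC)c1OC`) reads <= 1 h and that reading is a limit, not a number. Compound 2 (`COc1cc(/C=C/C(=O)O[C@H]2CC[C@@H](N(C)CCCCOC(=O)c3cc(OC)c(OC)c(OC)c3)CC2)cc(OC)c1OC`) reads >= 4 h and that reading is likewise a limit. Of the two values shown, compound 2 therefore holds the long-lived end, although no exact half-life is known for it.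

Compound 3 (`COc1cc(/C=C/C(=O)O[C@H]2CC[C@H](N(C)CCCCOC(=O)c3cc(OC)c(OC)c(OC)c3)CC2)cc(OC)c1OC`) has not yet been measured. It has the same atoms and bonds as compound 2 and differs only in configuration as drawn. The difference is summed up as the two compounds have the same atoms and bonds and differ only in configuration as drawn: 2 of 3 stereo elements differ; a stereocentre at a saturated ring carbon is drawn s in compound 2 and r in compound 3; a stereocentre at a saturated ring carbon is drawn s in compound 2 and r in compound 3 and in each case a stereocentre at a saturated ring carbon is drawn s in compound 2 and r in compound 3.

Among the measured compounds shown here, no measured step shows what such a change does in this assay and so no shift beyond the scatter is expected in either direction. The expected step of a number no higher from compound 2 to compound 3 (the limit leaves the size open) is accordingly estimated to stay within the scatter. For compound 3 the estimated half-life is 4 h with an expected range from 1.5 h to 8 h on this estimate.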

Compound 3, half-life: <= 2 h
Compound 3 ended at the assay's limit; the forecaster's own chance of this, stated with the estimate: 55%; middle value at least 2.0-fold (0.30 log units) away from the limit.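

In this assay, among the compounds shown here, this is the first readable step between compounds that differ in one place, and it concerns configuration alone: an at least 2.0-fold lower number from compound 2 to compound 3 (0.30 log units; that floor lies within the scatter). Both readings behind it are limits of the assay, so the step gives a floor for the size of the change and not the size itself, and that floor does not go beyond the usual scatter. Any real gap between these two compounds could rest on nothing but the drawn configuration at the two saturated ring carbons, because no atom or bond changes: the fact that compounds 2 and 3 differ only in the configuration as drawn

The compounds shown leave open the exact half-lives of compound 2 and compound 3, and with them the true size of the step and whether it goes beyond the scatter. They also leave open whether the same change of configuration would read the same way with a longer chain, or with an amide in place of the ester groups, and which of the two stereocentres carries any difference.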